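Chain-terminal oxygen-to-sulfur swap in the oxazole ketone series

The compounds below may be only part of what the source reports. "The series", "measured", "known", "first", "only" and "open" are said of these compounds alone.

Measured so far:
compound 1 `O=Cc1ccc(-c2cnc(C(=O)CCCCCCc3ccccc3)o2)nc1`, 2.2 nM
compound 2 `CSCc1ccc(-c2cnc(C(=O)CCCCCCc3ccccc3)o2)nc1`, 11.1 nM
compound 3 `COCOCCCCCc1cnc(C(=O)CCCCCCc2ccccc2)o1`, 24.1 nM

All values come from an assay for inhibition of Fatty-acid amide hydrolase 1 (Rattus norvegicus), using a Dixon plot; on this read-out lower numbers stand for stronger inhibition and higher numbers for weaker inhibition. Compound 3 stands at the weak end of the three: a 2.2-fold higher number from compound 2 to compound 3 (0.34 log units; beyond the scatter) and an 11-fold higher number from compound 1 to compound 3 (1.04 log units; beyond the scatter), both beyond the scatter. Compound 4 `CSCCCCCc1cnc(C(=O)CCCCCCc2ccccc2)o1` differs from compound 3 by methylsulfanyl in place of methoxymethoxy on a saturated chain carbon, five bonds along the chain from an aromatic carbon. Among the measured compounds shown here, no measured step makes exactly this swap; the nearest is a 5.0-fold higher number from compound 1 to compound 2 (0.70 log units; beyond the scatter), which brings in a methylsulfanyl group on an aromatic carbon and is a modest, not large, change. Compound 2, the other compound carrying a methylsulfanyl group, sits at a lower number than compound 3. A small step is therefore expected for compound 4, a 1.6-fold lower number from compound 3 to compound 4 (0.21 log units; within the scatter), toward a lower number but possibly within the scatter. Compound 4 is estimated at 15 nM, range 6 nM to 40 nM.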

Compound 4, inhibition constant: 8.1 nM
The estimate for compound 4 lay 1.9-fold (0.27 log units) above the measured number, and the stated range covers the measured number.
By their numbers in this assay, from the lowest: compound 1; then compounds 4 and 2 (each within the scatter of the next); then compound 3.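

On the saturated chain, methylsulfanyl in place of methoxymethoxy gives a direct reading of this swap at this position (a 3.0-fold lower number from compound 3 to compound 4 (0.47 log units; beyond the scatter)). With that group at the chain end, the acyclic compound cannot be told apart from the ring-bearing methylsulfanyl compound (a 1.4-fold lower number from compound 2 to compound 4 (0.14 log units; within the scatter)), while the formyl compound keeps its advantage (a 3.7-fold higher number from compound 1 to compound 4 (0.57 log units; beyond the scatter)). No evidence on the origin of these steps is available.

Still open, as far as these compounds go, is whether the change follows the sulfur atom or the smaller group. A methoxy or an amine on the same chain would separate these readings.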